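This account rests on a few compounds, and the source may have more. Where it says the series, first, only, none or still open, it means among the compounds named here.

Among the compounds with values here, in a functional assay on HT-29 cells (Homo sapiens) for antiproliferative activity, read by MTT assay, with a stated time of 72 h (on this read-out lower numbers stand for stronger inhibition and higher numbers for weaker inhibition), compound 1 `Nc1nc(N)c2cc(CSC(=S)N3CCN(c4ccccc4)CC3)ccc2n1` gives 2760 nM and compound 2 `Nc1nc(N)c2cc(CSC(=S)N3CCN(c4ccc(F)cc4)CC3)ccc2n1` gives 2050 nM, so compound 2 stands within the scatter of compound 1, the only other measured compound. Compound 3 `CC(=O)c1ccc(N2CCN(C(=S)SCc3ccc4nc(N)nc(N)c4c3)CC2)cc1` differs from compound 2 by acetyl in place of fluoro on an aromatic carbon, with acetyl in place of fluoro on an aromatic carbon. Within the data shown here, one measured step bears on this, a 1.3-fold lower number from compound 1 to compound 2 (0.13 log units; within the scatter), which swaps hydrogen for fluoro on the same carbon. Among the measured compounds shown here, no acetyl compound has been measured, so no shift beyond the scatter is expected in this assay. The expected step is a 1.1-fold higher number from compound 2 to compound 3 (0.03 log units; within the scatter). The estimate for compound 3 is 2200 nM, with an expected range of 900 nM to 5500 nM.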

Compound 3, half-maximal inhibitory concentration: 2280 nM
Compound 3: the middle estimate sits 1.0-fold (0.02 log units) below what was measured; measured number inside the range.
By their numbers in this assay, from the lowest: compounds 2, 3 and 1 (each within the scatter of the next).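

In this assay, the step from fluoro to acetyl at the carbon para to a large group reads a 1.1-fold higher number from compound 2 to compound 3 (0.05 log units; within the scatter), and the step from hydrogen to acetyl at that carbon reads a 1.2-fold lower number from compound 1 to compound 3 (0.08 log units; within the scatter). The position therefore takes a group of 3 heavy atoms with a hydrogen-bond acceptor, not only a single fluorine, with no shift beyond the scatter. No supporting measurement is available to explain this result. Going by these compounds, whether an amine, a carboxylic acid or a longer chain on this carbon would shift the number beyond the scatter remains open.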